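Benzylamine swap on two cores: permeability notes

The source may hold more compounds than are shown below. What is called first, only, known or untested is meant among the compounds shown, and "the series" means these compounds.

In an ADME assay for permeability, using PAMPA, with a stated time of 30 min, at pH 7.4 (on this read-out higher numbers stand for higher permeability and lower numbers for lower permeability), compound 1 `COc1ccc(F)cc1CNCCCNc1ccnc2cc(Oc3cccc(N(C)C)c3)ccc12` gives 317 10^-6 cm/s. Compound 2 `COc1cccc(CNCCCNc2ccnc3cc(Oc4cccc(N(C)C)c4)ccc23)c1O` differs by 2-hydroxy-3-methoxyphenyl in place of 5-fluoro-2-methoxyphenyl on a saturated chain carbon bound to an amine nitrogen and in this assay compound 2 gives 317 10^-6 cm/s; the step is no change at the digits printed from compound 1 to compound 2 (within the scatter). Compound 3 `COc1ccc(F)cc1CNCCCNc1ccnc2cc(CCc3ccccc3)ccc12` carries a different core, the difference being (phenethyl in place of 3-(dimethylamino)phenoxy on an aromatic carbon). In this assay compound 3 gives 23 10^-6 cm/s, the step being a 14-fold lower number from compound 1 to compound 3 (1.14 log units; beyond the scatter), the lowest number of the three. Compound 4 `COc1cccc(CNCCCNc2ccnc3cc(CCc4ccccc4)ccc23)c1O` is not yet measured in this assay; it differs from compound 3 by 2-hydroxy-3-methoxyphenyl in place of 5-fluoro-2-methoxyphenyl on a saturated chain carbon bound to an amine nitrogen, the same change as between compound 1 and compound 2, at the same place. The step from compound 3 to compound 4 is expected to be no change at the digits printed from compound 3 to compound 4 (within the scatter), resting on the flat step no change at the digits printed from compound 1 to compound 2 (within the scatter) seen on the other core, a single pairing. Compound 4 is therefore estimated at 23 10^-6 cm/s, expected between 11 10^-6 cm/s and 46 10^-6 cm/s.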

Compound 4, apparent permeability: 23 10^-6 cm/s
Beside the measured number, compound 4's estimate shows no gap at the digits printed, within the range that was stated.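

In this assay the swap of 5-fluoro-2-methoxyphenyl for 2-hydroxy-3-methoxyphenyl gives no change at the digits printed from compound 3 to compound 4 (within the scatter), the same flat result as on the core of compound 1: the same change on two cores in this assay, no change at the digits printed (within the scatter) from compound 1 to compound 2 and no change at the digits printed (within the scatter) from compound 3 to compound 4, 1.0-fold (0.00 log units) apart, within the scatter of two such steps

The change from 3-(dimethylamino)phenoxy to phenethyl, read with 2-hydroxy-3-methoxyphenyl in place, gives a 14-fold lower number from compound 2 to compound 4 (1.14 log units; beyond the scatter), the same size as with 5-fluoro-2-methoxyphenyl: the same change on two cores in this assay, a 14-fold lower number (1.14 log units; beyond the scatter) from compound 1 to compound 3 and a 14-fold lower number (1.14 log units; beyond the scatter) from compound 2 to compound 4, 1.0-fold (0.00 log units) apart, within the scatter of two such steps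

Across these four compounds the two changes therefore read independently of each other, but this rests on one pair of cores and one pair of benzyl groups and shows nothing for other cores or groups.

Still open, from the compounds shown here alone, is whether the flat swap holds for a benzyl group carrying a carboxylic acid or an amine. Also open, going by these compounds, is whether the core step keeps its size with a longer chain.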